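From Trifluoromethylphenyl to Pyridinyl on the Ring Nitrogen

The source may hold more compounds than are shown below. What is called first, only, known or untested is meant among the compounds shown, and "the series" means these compounds.

Three compounds share one core and differ only in the group carried on an amine nitrogen in a ring. Compound 1 `CC(C)N1CCN(Cc2csc(N)c2C(=O)c2ccc(Cl)cc2)CC1` carries isopropyl there, and in a functional assay on CHO cells with adenosine receptor A1 (Homo sapiens) as the target, read by cAMP accumulation and immunoassay, with a stated time of 6 min, tested at 1 uM (on this read-out higher numbers stand for a weaker effect at the one concentration tested and lower numbers for a stronger effect), compound 1 gives 7.3%. Compound 2 `Nc1scc(CN2CCN(c3cc(Cl)cc(Cl)c3)CC2)c1C(=O)c1ccc(Cl)cc1` carries 3,5-dichlorophenyl and in this assay compound 2 gives -69%, while compound 3 `Nc1scc(CN2CCN(c3cccc(C(F)(F)F)c3)CC2)c1C(=O)c1ccc(Cl)cc1` carries 3-(trifluoromethyl)phenyl and gives -72%. Compound 3 and compound 2 stand together at the low end of the three; their gap, a number 3 percentage points lower from compound 2 to compound 3 (within the scatter), is within the scatter, so the two cannot be ranked. Only compound 1 stands clearly apart, with a number 76.3 percentage points lower from compound 1 to compound 2 (beyond the scatter) and a number 79.3 percentage points lower from compound 1 to compound 3 (beyond the scatter).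

Compound 4 `Nc1scc(CN2CCN(c3ccncc3)CC2)c1C(=O)c1ccc(Cl)cc1` differs from compound 3 in one place: pyridin-4-yl in place of 3-(trifluoromethyl)phenyl on an amine nitrogen in a ring. Among the compounds with values here, the steps that bear on this change are the two large drops from the isopropyl compound to either aryl compound, and the gap between the two aryl compounds, which lies within the scatter. Pyridin-4-yl is again a six-membered aromatic ring, so only a small step is expected, a number 17 percentage points higher from compound 3 to compound 4 (beyond the scatter), if anything toward a higher number. Compound 4 is therefore estimated at -55%, with a range from -90% to -10%.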

Compound 4, a percentage reported as activity, at one concentration (the size of the read-out at that concentration, not a potency): -8.3%
The estimate for compound 4 lay 46.7 percentage points below the measured number; the whole stated range lies below it.
By their numbers in this assay, from the lowest: compounds 3 and 2 (each within the scatter of the next); then compound 4; then compound 1.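

Compound 4 shows that a six-membered aromatic ring on this amine nitrogen does not by itself give the strongly negative numbers seen with the two substituted phenyl groups. In this assay, the change to pyridin-4-yl gives a number 63.7 percentage points higher from compound 3 to compound 4 (beyond the scatter) and a number 60.7 percentage points higher from compound 2 to compound 4 (beyond the scatter), both large steps that reverse most of the drop seen on going from isopropyl to either substituted phenyl group. The ring still counts for something, with a number 15.6 percentage points lower from compound 1 to compound 4 (beyond the scatter), a modest step, but the swap removes the trifluoromethyl group and also places a nitrogen in the ring, and nothing at hand separates these two changes or explains the rise.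

The compounds shown leave open whether the loss follows the ring nitrogen or the missing substituent, a question that plain phenyl or a pyridin-4-yl ring carrying trifluoromethyl or chlorine could help settle. Because each number comes from a single concentration, they also leave open how these steps would translate into potency, and whether a saturated ring such as cyclohexyl would sit closer to isopropyl or to the aryl groups.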